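The source may hold more compounds than are shown below. What is called first, only, known or untested is meant among the compounds shown, and "the series" means these compounds.

Measured so far:
compound 1, `O=C(CCCCCCc1ccccc1)c1ncc(-c2cccc(O)c2)o1`: 50 nM
compound 2, `O=C(CCCCCCc1ccccc1)c1ncc(-c2nnn[nH]2)o1`: 63 nM
compound 3, `CN(C)C(=O)c1cnc(C(=O)CCCCCCc2ccccc2)o1`: 2 nM

All three were tested in an assay (Rattus norvegicus) for inhibition of Fatty-acid amide hydrolase 1 (Homo sapiens) (on this read-out lower numbers stand for stronger inhibition and higher numbers for weaker inhibition), and share one core, differing only in the group carried on an aromatic carbon. Compound 3 gives the lowest number of the three: a 25-fold lower number from compound 1 to compound 3 (1.40 log units; beyond the scatter) and a 32-fold lower number from compound 2 to compound 3 (1.50 log units; beyond the scatter) are both large, whereas a 1.3-fold higher number from compound 1 to compound 2 (0.10 log units; within the scatter) lies within the scatter. Compound 4, `O=C(CCCCCCc1ccccc1)c1ncc(C(=O)C(F)(F)F)o1`, keeps the carbonyl group of compound 3 but changes what sits on the carbonyl carbon: trifluoromethyl in place of dimethylamino on a carbonyl carbon. Among the compounds with values here, none of the measured steps touches this change directly; the two large steps into compound 3 show only that the group on this aromatic carbon can move the number strongly, so the change to compound 4 could be large in either direction. Lacking a direct comparison, the expected step is kept small, a 2.5-fold higher number from compound 3 to compound 4 (0.40 log units; beyond the scatter), with a wide margin. Compound 4 is therefore expected to give about 5 nM, in the range 0.5 nM to 50 nM.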

Compound 4, inhibition constant: 4 nM
For compound 4 the middle estimate is 1.3-fold (0.10 log units) above the measured one, within the range that was stated.
By their numbers in this assay, from the lowest: compounds 3 and 4 (each within the scatter of the next); then compounds 1 and 2 (each within the scatter of the next).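

In this assay the swap on the carbonyl carbon gives a 2.0-fold higher number from compound 3 to compound 4 (0.30 log units; within the scatter) and so leaves the number within the scatter, even though trifluoromethyl and dimethylamino share no atom type other than carbon. The low numbers are thus not tied to the dimethylcarbamoyl group alone: the group on the aromatic carbon can be (trifluoromethyl)carbonyl as well, which shows as a 16-fold lower number from compound 2 to compound 4 (1.20 log units; beyond the scatter) and as a 13-fold lower number from compound 1 to compound 4 (1.10 log units; beyond the scatter) in two large steps. Among the compounds shown, both groups with a carbonyl on this aromatic carbon give low numbers, while 1H-tetrazol-5-yl and 3-hydroxyphenyl give higher ones, and no supporting measurement is available to explain either the match or the gap.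

As far as these compounds go, whether a methyl ketone, a methyl ester or a carboxylic acid on this aromatic carbon would join compound 3 and compound 4 stays open. So does whether a nitrile, which has no carbonyl, would give a number as low.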